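The source may report more compounds than this note shows. Statements on the series, on what has been measured and on what is new or still open speak of the compounds shown alone.

Working notes on the series. Compound 1 `Cc1cc(Nc2cc(N3CCN(C)CC3)nc(Nc3ccc(F)cc3)n2)n[nH]1` carries a 4-fluorophenyl on the aromatic nitrogen of the shared core, and compound 2 `COc1ccc(Nc2nc(Nc3cc(C)[nH]n3)cc(N3CCN(C)CC3)n2)cc1OC` a 3,4-dimethoxyphenyl at the same place. In a functional assay on HCT-116 cells (Homo sapiens) for antiproliferative activity, read by CCK-8 assay, with a stated time of 48 h (a lower number here means a stronger inhibitor, a higher number a weaker inhibitor), compound 1 gives 653 nM, and in this assay compound 2 gives 777 nM. Compound 2 thus stands beside compound 1, the two numbers lying within the scatter of each other, as the step of a 1.2-fold higher number from compound 1 to compound 2 (0.08 log units; within the scatter) shows. Compound 3 `Cc1cc(Nc2cc(N3CCN(C)CC3)nc(Nc3ccc(Cl)c(F)c3)n2)n[nH]1` differs from compound 2 in one place: 4-chloro-3-fluorophenyl in place of 3,4-dimethoxyphenyl on a nitrogen on an aromatic ring. For the measured compounds named here, the only measured step that bears on exchanging this aryl group is a 1.2-fold higher number from compound 1 to compound 2 (0.08 log units; within the scatter), which stayed within the scatter, so no movement in this assay beyond the scatter is expected for the step from compound 2 to compound 3, and the estimated step of a 1.3-fold lower number from compound 2 to compound 3 (0.10 log units; within the scatter) reflects this. Compound 3 is therefore expected to give 620 nM in this assay, with a range from 250 nM to 1500 nM.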

Compound 3, half-maximal inhibitory concentration: 252 nM
For compound 3 the middle estimate is 2.5-fold (0.39 log units) above the measured one; measured number inside the range.
By their numbers in this assay, from the lowest: compound 3; then compounds 1 and 2 (each within the scatter of the next).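

The aryl group on this nitrogen can move the number in this assay beyond the scatter, which the exchange between 4-fluorophenyl and 3,4-dimethoxyphenyl did not show: the change gives a 3.1-fold lower number from compound 2 to compound 3 (0.49 log units; beyond the scatter) and a 2.6-fold lower number from compound 1 to compound 3 (0.41 log units; beyond the scatter). Among these three compounds, 4-chloro-3-fluorophenyl therefore stands alone at the low end, with the two other aryl groups within the scatter of each other. No measurement at hand accounts for this difference.

The compounds shown leave open whether the chlorine alone carries the step, which a plain 4-chlorophenyl on the same nitrogen would test against compound 1 and compound 3. Also open, going by these compounds, is how an aryl group bearing a trifluoromethyl or a nitrile, or one bearing an amine or a carboxylic acid, would read in this assay.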